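A Smaller, Oxygen-Bearing Ring in Place of Cyclohexyl

The source may report more compounds than this note shows. Statements on the series, on what has been measured and on what is new or still open speak of the compounds shown alone.

Measured so far:
compound 1 `CN(C(=O)N1CC[C@H](n2cnc3cc(-c4ccc(Cl)cc4)sc3c2=O)C1)[C@H]1CCN(C2CCC2)C1` gives 1 nM in an assay on isolated protein for binding affinity to melanin-concentrating hormone receptor 1 (Homo sapiens); a higher number here means a weaker inhibitor, a lower number a stronger inhibitor
compound 2 `CN(C(=O)N1CC[C@H](n2cnc3cc(-c4ccc(Cl)cc4)sc3c2=O)C1)[C@H]1CCN(CC2CCCCC2)C1` gives 50 nM in this assay

Within the data shown here, compound 2 holds the higher of the two numbers recorded; its nearest neighbour is compound 1, and the only measured step, a 50-fold higher number from compound 1 to compound 2 (1.70 log units; beyond the scatter), separates them. Compound 3 `CN(C(=O)N1CC[C@H](n2cnc3cc(-c4ccc(Cl)cc4)sc3c2=O)C1)[C@H]1CCN(CC2CCOC2)C1` has not been measured yet. It differs from compound 2 in one place: oxolan-3-yl in place of cyclohexyl on a saturated chain carbon bound to an amine nitrogen in a ring. Among the measured compounds shown here, no measured step changes the ring at this position; the one step that exists, a 50-fold higher number from compound 1 to compound 2 (1.70 log units; beyond the scatter), changed instead what sits directly on the amine nitrogen in a ring, and it was large. It shows that the numbers respond strongly to what is attached in this region, but it does not tell how an oxygen-containing five-membered ring compares with cyclohexyl. For the measured compounds named here, with that step as the only guide, a move back toward the number of compound 1 is expected, but of smaller size and with wide uncertainty. The estimate for compound 3 is therefore 20 nM, with a range from 4 nM to 120 nM, which would mean a 2.5-fold lower number from compound 2 to compound 3 (0.40 log units; beyond the scatter).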

Compound 3, inhibition constant: 4 nM
Compound 3: middle estimate off by 5.0-fold (0.70 log units), on the high side; the range from low to high includes it.
By their numbers in this assay, from the lowest: compound 1; then compound 3; then compound 2.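

Changing only the ring on the saturated chain carbon gives a 13-fold lower number from compound 2 to compound 3 (1.10 log units; beyond the scatter) in this assay, so the ring at the end of this side chain matters strongly, and not only the group directly on the amine nitrogen in a ring. The comparison with the small cyclobutyl group gives a 4.0-fold higher number from compound 1 to compound 3 (0.60 log units; beyond the scatter), a modest step, which shows that a larger (oxolan-3-yl)methyl group on this nitrogen does not have to carry the full penalty seen with cyclohexylmethyl, even though compound 3 does not fully match compound 1. Nothing available here offers an explanation for why oxolan-3-yl gives a lower number than cyclohexyl.

The step from cyclohexyl to oxolan-3-yl changes the ring size and brings in an oxygen at the same time, so these compounds cannot show how much of the difference belongs to each change. As far as these compounds go, a cyclopentyl group at the same place would have a five-membered ring of carbon only, an oxan-4-yl group would keep the oxygen in a six-membered ring, and how either would behave in this assay remains open.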